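A few compounds are considered here, and "the series" means these few. Any claim that something is new, unique, unknown or untested is made for them only; others in the source may bear on it.

Compound 2 `COc1cc(/C=C/C(=O)NNC(=O)c2ccccc2)cc(OC)c1O` stands at > 10000 nM in a functional assay on MCF7 cells (Homo sapiens) for antiproliferative activity, read by MTT assay, with a stated time of 24 h (a higher number here means a weaker inhibitor, a lower number a stronger inhibitor), which is a limit of the assay and not a number. In this assay compound 1 `COc1ccc(C(=O)NNC(=O)/C=C/c2ccc(O)c(OC)c2)cc1` gives 5620 nM. Compound 3 `COc1ccc(C(=O)NNC(=O)/C=C/c2cc(OC)c(O)c(OC)c2)cc1` departs from compound 2 by methoxy in place of hydrogen on an aromatic carbon, or phenyl to 4-methoxyphenyl. For the measured compounds named here, no measured step is available to size this change. Compound 1, at 5620 nM, also carries the 4-methoxyphenyl, so a modest gain in strength is expected. The expected move is an at least 1.6-fold lower number from compound 2 to compound 3 (0.22 log units; that floor lies within the scatter). For compound 3 the estimate is 6000 nM, with an expected range of 2000 nM to 10000 nM.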

Compound 3, half-maximal inhibitory concentration: 7170 nM
Beside the measured number, compound 3's estimate is 1.2-fold (0.08 log units) below it; the range from low to high includes it.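

Phenyl to 4-methoxyphenyl gives an at least 1.3-fold lower number from compound 2 to compound 3 (0.14 log units; that floor lies within the scatter). Compound 2 is a limit of the assay and not a number, so this step gives only a floor for the change at this position: the limit of > 10000 nM in this assay, at which 1 of the 3 values shown sits.

Methoxy in place of hydrogen at a different aromatic carbon gives a 1.3-fold higher number from compound 1 to compound 3 (0.11 log units; within the scatter), so this second change separates compound 1 and compound 3 by no more than the usual scatter.

Going by these compounds, it remains open whether the true size of the phenyl to 4-methoxyphenyl change exceeds the scatter. On these data alone, how an amine or a carboxylic acid would read in place of this methoxy also remains open.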